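The compounds below may be only part of what the source reports. "The series", "measured", "known", "first", "only" and "open" are said of these compounds alone.

Compound 1 `O=C1/C(=C\c2ccccc2)c2c(ncn2COCc2ccccc2)CCN1Cc1ccc(F)cc1` gives 19600 nM
Compound 2 `Cc1cc(C)cc(CN2CCc3ncn(COCc4ccccc4)c3/C(=C/c3ccccc3)C2=O)c1` gives 22500 nM
Compound 3 `Cc1cccc(CN2CCc3ncn(COCc4ccccc4)c3/C(=C/c3ccccc3)C2=O)c1` gives 16100 nM

These values come from a functional assay on A549 cells (Homo sapiens) for inhibition, read by MTT assay, with a stated time of 72 h; a higher number here means a weaker inhibitor, a lower number a stronger inhibitor. Compound 3 cannot be told apart from the other two, with a 1.2-fold lower number from compound 1 to compound 3 (0.09 log units; within the scatter) and a 1.4-fold lower number from compound 2 to compound 3 (0.15 log units; within the scatter) as its steps. Compound 4 `COc1ccc(CN2CCc3ncn(COCc4ccccc4)c3/C(=C/c3ccccc3)C2=O)cc1` has 4-methoxyphenyl in place of 3-methylphenyl on a saturated chain carbon bound to an amide-type nitrogen in a ring. Going by the values given here, no measured compound carries this new group, so the expectation is uncertain. The closest evidence is another swap of this group, a 1.1-fold higher number from compound 1 to compound 2 (0.06 log units; within the scatter), so no step beyond the scatter is expected in this assay. The expected result is a 1.1-fold higher number from compound 3 to compound 4 (0.05 log units; within the scatter). For compound 4 the estimated value is 18000 nM with an expected range from 9000 nM to 33000 nM.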

Compound 4, half-maximal inhibitory concentration: 46800 nM
Compound 4: the middle estimate sits 2.6-fold (0.41 log units) below what was measured; the measured number lies above the stated range.
By their numbers in this assay, from the lowest: compounds 3, 1 and 2 (each within the scatter of the next); then compound 4.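

With a 2.9-fold higher number from compound 3 to compound 4 (0.46 log units; beyond the scatter) and a 2.1-fold higher number from compound 2 to compound 4 (0.32 log units; beyond the scatter) and a 2.4-fold higher number from compound 1 to compound 4 (0.38 log units; beyond the scatter) as its steps, compound 4 is the weakest of the four in this assay and the first to show that this position can move the number beyond the scatter, though only modestly. Its step from compound 1 is a single swap of methoxy for fluoro on an aromatic carbon, so one small change on the phenyl ring is enough. Nothing available here explains this result.

From the compounds shown here alone, whether 3-methoxyphenyl would behave like 4-methoxyphenyl stays open. So does the effect of an amine or a carboxylic acid on that phenyl ring.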